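Extending the chain from compound 2 to compound 4

The source may report more compounds than this note shows. Statements on the series, on what has been measured and on what is new or still open speak of the compounds shown alone.

In a functional assay on MDA-MB-231 cells (Homo sapiens) for cytotoxicity, read by MTT assay, with a stated time of 24 h (a higher number here means a weaker inhibitor, a lower number a stronger inhibitor), compound 2 (`CCCCCCCC(=O)Nc1nnc(S[C@@H]2O[C@H](CO)[C@H](O)[C@H](O)[C@H]2O)s1`) gives 30800 nM. This lies within the scatter of compound 1 (`CCCCCCCCCCCCCC(=O)Nc1nnc(S[C@@H]2O[C@H](COC(C)=O)[C@H](OC(C)=O)[C@H](OC(C)=O)[C@H]2OC(C)=O)s1`) at 26200 nM and of compound 3 (`CCCCCC(=O)Nc1nnc(S[C@@H]2O[C@H](COC(C)=O)[C@H](OC(C)=O)[C@H](OC(C)=O)[C@H]2OC(C)=O)s1`) at 25400 nM. Compound 4 (`C=CCCCCCCCCC(=O)Nc1nnc(S[C@@H]2O[C@H](CO)[C@H](O)[C@H](O)[C@H]2O)s1`) differs from compound 2 by allyl in place of hydrogen on a saturated chain carbon, seven bonds along the chain from a carbonyl carbon; cut further out, this reads propyl to hex-5-en-1-yl. For the measured compounds named here, the only measured chain change, hydrogen in place of octyl, gave a 1.0-fold lower number from compound 1 to compound 3 (0.01 log units; within the scatter), within the scatter, and that pair carries acetyl groups that compound 2 lacks. No shift beyond the scatter is therefore expected in this assay, and the estimated 1.1-fold lower number from compound 2 to compound 4 (0.06 log units; within the scatter) is small. Compound 4 is expected at 27000 nM, with an estimated range of 14000 nM to 50000 nM.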

Compound 4, half-maximal inhibitory concentration: 80600 nM
Beside the measured number, compound 4's estimate is 3.0-fold (0.47 log units) below it, and the stated range ends below it.
By their numbers in this assay, from the lowest: compounds 3, 1 and 2 (each within the scatter of the next); then compound 4.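

In this assay, allyl in place of hydrogen on a saturated chain carbon, seven bonds along the chain from a carbonyl carbon, gives a 2.6-fold higher number from compound 2 to compound 4 (0.42 log units; beyond the scatter), toward weaker inhibition. This is the first chain change shown to pass the scatter, whereas a 1.0-fold lower number from compound 1 to compound 3 (0.01 log units; within the scatter) did not, and that pair carries acetyl groups. No measurement shown bears on why the number rises. Open, from the compounds shown here alone, is whether a saturated chain of the same length would shift the number as far as the hex-5-en-1-yl end does. Also open, going by these compounds, is how a terminal amine would read at this position.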